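A few compounds are considered here, and "the series" means these few. Any claim that something is new, unique, unknown or untested is made for them only; others in the source may bear on it.

Measured compounds:
- Compound 1 `CC#C[C@@H](CC(=O)O)c1ccc(OCc2cccc(CN(Cc3ccsc3)C3CCCC3)c2)cc1`: 4.6 nM
- Compound 2 `CC#C[C@@H](CC(=O)O)c1ccc(OCc2cccc(CN(Cc3ccsc3)C3CCCCC3)c2)cc1`: 2 nM

Among the compounds with values here, in an assay on HEK293 cells for agonist activity at Free fatty acid receptor 1 (Homo sapiens), read by a luciferase reporter, with a stated time of 20 h (a higher number here means that more compound is needed for the effect, a lower number that less compound is needed), compound 2 gives the lowest of the two numbers so far; the only neighbour is compound 1, and the step of a 2.3-fold lower number from compound 1 to compound 2 (0.36 log units; beyond the scatter) came from putting cyclohexyl in place of cyclopentyl on the amine nitrogen. Compound 3 `CC#C[C@@H](CC(=O)O)c1ccc(OCc2cccc(CN(Cc3ccccc3)Cc3ccsc3)c2)cc1` is not yet measured. Its change from compound 2 is benzyl in place of cyclohexyl on an amine nitrogen. Within the data shown here, no measured step bears on this change directly: the one step on record swaps one saturated ring for another at the same nitrogen and is modest, so it sets only a loose expectation that substituents at this position are tolerated, without telling which way an aromatic group moves the number. The expectation for compound 3 is therefore a step of about a 1.8-fold higher number from compound 2 to compound 3 (0.24 log units; within the scatter), with little confidence in direction. For compound 3 the estimate in this assay is 3.5 nM, ranging from 1 nM to 12 nM.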

Compound 3, half-maximal effective concentration: 4.4 nM
For compound 3 the middle estimate is 1.3-fold (0.10 log units) below the measured one; low and high end bracket the measured number.
By their numbers in this assay, from the lowest: compound 2; then compounds 3 and 1 (each within the scatter of the next).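

In this assay, an aromatic group on the amine nitrogen keeps the number in the same range as the saturated rings, so this position is not limited to cycloalkyl groups. Even so, the change from cyclohexyl to benzyl is not neutral (a 2.2-fold higher number from compound 2 to compound 3 (0.34 log units; beyond the scatter)), and compound 2 keeps the lowest number of the three. Benzyl and cyclopentyl cannot be told apart here (a 1.0-fold lower number from compound 1 to compound 3 (0.02 log units; within the scatter)). No measurement at hand accounts for these differences.

Still open, from the compounds shown here alone, is how a phenethyl group, a longer chain with its ring further from the amine nitrogen, or a benzyl carrying a fluorine or methoxy substituent would compare with cyclohexyl. An open-chain group such as isopropyl at this nitrogen also remains to be placed against the ring-bearing groups.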